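The source may report more compounds than this note shows. Statements on the series, on what has been measured and on what is new or still open speak of the compounds shown alone.

Series notes. The parent ester compound 1 `CCCCN1CCC(COC(=O)c2ccc(N)c3c2OCCO3)CC1` gives 1.4 nM in an assay on HEK293 cells for displacement of a labelled ligand from 5-hydroxytryptamine receptor 4 (Homo sapiens); on this read-out lower numbers stand for stronger inhibition and higher numbers for weaker inhibition. Compound 2 `CCCCN1CCC(COC(=O)c2cc(C#N)c(N)c3c2OCCO3)CC1` gives 33 nM in this assay and stands second highest of the three numbers; its nearest neighbour is compound 3 `CCCCN1CCC(COC(=O)c2cc(C#N)c(NC)c3c2OCCO3)CC1`, which gives 37 nM in this assay, and its furthest is compound 1. The measured steps are a 24-fold higher number from compound 1 to compound 2 (1.37 log units; beyond the scatter) and a 1.1-fold higher number from compound 2 to compound 3 (0.05 log units; within the scatter). Compound 4 `CCCCN1CCC(COC(=O)c2cc([N+](=O)[O-])c(N)c3c2OCCO3)CC1` differs from compound 2 by nitro in place of cyano on an aromatic carbon. Neither measured step exchanges one such group for another: one introduces the cyano group onto the core, the other alters the amino group. For the measured compounds named here, no step bears directly on this exchange, so no change beyond the scatter in this assay is expected. Compound 4 is accordingly estimated at 30 nM, range 10 nM to 100 nM, an expected 1.1-fold lower number from compound 2 to compound 4 (0.04 log units; within the scatter).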

Compound 4, inhibition constant: 7.8 nM
Compound 4: the middle estimate sits 3.8-fold (0.59 log units) above what was measured; measured number below the stated range.
By their numbers in this assay, from the lowest: compound 1; then compound 4; then compounds 2 and 3 (each within the scatter of the next).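

In this assay this aromatic carbon, ortho to an amino group, distinguishes between substituents: exchanging cyano for nitro gives a 4.2-fold lower number from compound 2 to compound 4 (0.63 log units; beyond the scatter), so the identity of the group counts, not only its presence. The nitro group still does not reach the level of the unsubstituted parent, with a 5.6-fold higher number from compound 1 to compound 4 (0.75 log units; beyond the scatter). No measurement at hand accounts for the difference between the two groups.

Going by these compounds, whether chloro or a carboxylic acid at this carbon would come closer to compound 1 remains open. Also open, on these data alone, is whether methyl on the amino nitrogen would leave the number unchanged with nitro present, as it does with cyano.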